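Ring substituent swap on the shared core

The source may hold more compounds than are shown below. What is called first, only, known or untested is meant among the compounds shown, and "the series" means these compounds.

Measured compounds:
compound 1 `CN1CCN(c2ccc3c(c2)oc(=O)n3C(=O)NCCCCc2ccccc2)CC1=O`: 92 nM
compound 2 `CN1CCC(c2ccc3c(c2)oc(=O)n3C(=O)NCCCCc2ccc(F)cc2)CC1`: 94 nM
compound 3 `CCCCCNC(=O)n1c(=O)oc2cc(C3CCN(C)CC3)ccc21`: 396 nM

In an assay on HEK293 cells for inhibition of acid ceramidase (Homo sapiens), read by fluorescence, with stated times of 10 min and 3 h (a lower number here means a stronger inhibitor, a higher number a weaker inhibitor), compound 1 gives the lowest of the three numbers. Compound 2 lies within the scatter of compound 1, so the two cannot be ordered. Within the data shown here, the only single-place step among the measured compounds is a 4.2-fold higher number from compound 2 to compound 3 (0.62 log units; beyond the scatter), which replaces 4-fluorophenyl by methyl on a saturated chain carbon, four bonds along the chain from an amide-type nitrogen; it says nothing about the group on the aromatic carbon of the core.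

Compound 4 `CN1CCN(c2ccc3c(c2)oc(=O)n3C(=O)NCCCCc2ccccc2)CC1` differs from compound 1 by 4-methylpiperazin-1-yl in place of 4-methyl-3-oxopiperazin-1-yl on an aromatic carbon. Among the measured compounds shown here, no measured step bears on this change directly. The comparison of compound 1 with compound 2, which carries a different saturated ring on the core and sits within the scatter of compound 1, is the only hint, and it is not a single-place step. The expectation for compound 4 in this assay is therefore a step of a 1.1-fold higher number from compound 1 to compound 4 (0.04 log units; within the scatter), not beyond the scatter. Compound 4 is estimated at 100 nM, within 40 nM to 250 nM.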

Compound 4, half-maximal inhibitory concentration: 116 nM
Estimate against measurement, compound 4: 1.2-fold (0.06 log units) below; measured number inside the range.
By their numbers in this assay, from the lowest: compounds 1, 2 and 4 (each within the scatter of the next); then compound 3.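

In this assay, the change on an aromatic carbon of the shared core from 4-methyl-3-oxopiperazin-1-yl to 4-methylpiperazin-1-yl gives a 1.3-fold higher number from compound 1 to compound 4 (0.10 log units; within the scatter). Among these compounds, this is the first single-place step at this position, as the earlier step concerned only the chain, and compound 1 and compound 4 cannot be ordered: with the ring carbonyl present or absent, the measured numbers cannot be told apart. Nothing available on these compounds offers an explanation for this result.

Going by these compounds, it remains open whether a morpholin-4-yl group or an unsubstituted piperazin-1-yl group on the same aromatic carbon would also stay within the scatter of compound 1. On these data alone, it is also open whether the pair of groups compared here would give a similar step on the chain of compound 3.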